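Swapping the aryl group on a shared pyrimidine-piperidine scaffold

The source may report more compounds than this note shows. Statements on the series, on what has been measured and on what is new or still open speak of the compounds shown alone.

Compounds measured so far:
compound 1 `NS(=O)(=O)NCC1CCN(c2cc(-c3ccc(Cl)cc3)ncn2)CC1` — 25500 nM
compound 2 `COc1ccc(-c2cc(N3CCC(CCNS(N)(=O)=O)CC3)ncn2)cc1` — 56600 nM
compound 3 `NS(=O)(=O)NCCC1CCN(c2cc(-c3ccc(Cl)cc3)ncn2)CC1` — 19700 nM

In a functional assay on MCF7 cells (Homo sapiens) for antiproliferative activity, read by sulforhodamine B assay, with a stated time of 48 h (a higher number here means a weaker inhibitor of growth, a lower number a stronger inhibitor of growth), compound 3 gives the lowest of the three numbers. Its gap to compound 1 lies within the scatter, as a 1.3-fold lower number from compound 1 to compound 3 (0.11 log units; within the scatter) shows, whereas a 2.9-fold lower number from compound 2 to compound 3 (0.46 log units; beyond the scatter) is a modest step beyond it. Compound 4 `NS(=O)(=O)NCCC1CCN(c2cc(-c3ccccc3F)ncn2)CC1` differs from compound 3 by 2-fluorophenyl in place of 4-chlorophenyl on an aromatic carbon. Going by the values given here, only the step from compound 2 to compound 3 touches the aryl group, and it was modest; no measured step tests this exact swap. Compound 4 is therefore expected to land close to compound 3, with a step of a 1.8-fold higher number from compound 3 to compound 4 (0.25 log units; within the scatter), and its value in this assay is estimated at 35000 nM, ranging from 12000 nM to 100000 nM.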

Compound 4, concentration for 50% growth inhibition: > 100000 nM
Compound 4 gave a limit, no number (the forecaster's own chance of this, stated with the estimate: 10%); at least 2.8-fold (0.45 log units) between middle value and limit.
By their numbers in this assay, from the lowest: compounds 3 and 1 (each within the scatter of the next); then compound 2. At a limit, above all of these: compound 4.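

In this assay compound 4 gives a limit, not a number: the limit of > 100000 nM in this assay, at which 1 of the 4 values shown sits. Going by these compounds alone, the aryl group on the shared core therefore matters more than the earlier compounds showed, as 2-fluorophenyl in place of 4-chlorophenyl gives an at least 5.0-fold higher number from compound 3 to compound 4 (0.70 log units; beyond the scatter) and no earlier step reached that size. Against 4-methoxyphenyl the change gives only an at least 1.7-fold higher number from compound 2 to compound 4 (0.24 log units; that floor lies within the scatter) and so leaves the order of those two compounds unsettled.

Still open, as far as these compounds go, is whether the loss follows the halogen or its place on the phenyl ring. A 4-fluorophenyl or 2-chlorophenyl group would separate the two.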